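This account rests on a few compounds, and the source may have more. Where it says the series, first, only, none or still open, it means among the compounds named here.

Compound 2, `CC1(C)[C@H]2CC[C@]1(C)N(Cc1cn(-c3ccccc3)nn1)C(=O)C2`, gives 50 nM in a functional assay on OVCAR-3 cells (Homo sapiens) for inhibition, read by MTT assay, with a stated time of 24 h (a lower number here means a stronger inhibitor, a higher number a weaker inhibitor), the highest of the two numbers recorded so far; its nearest neighbour is compound 1, `Cc1ccc(-n2cc(CN3C(=O)C[C@@H]4CC[C@@]3(C)C4(C)C)nn2)cc1`, which gives 40 nM in this assay. Among the measured compounds shown here, the one step measured between these two, a 1.3-fold higher number from compound 1 to compound 2 (0.10 log units; within the scatter), is hydrogen in place of methyl on an aromatic carbon and lies within the scatter, so the two compounds cannot be ranked against each other. Compound 3, `CC1(C)[C@H]2CC[C@]1(C)N(Cc1cn(-c3ccccc3Cl)nn1)C(=O)C2`, differs from compound 2 by chloro in place of hydrogen on an aromatic carbon. For the measured compounds named here, no measured step concerns a chloro group, so the change has no direct precedent here; the only step on record, a 1.3-fold higher number from compound 1 to compound 2 (0.10 log units; within the scatter), was a different change and did not move the number beyond the scatter. Compound 3 is therefore expected to give about 50 nM in this assay, with a range from 20 nM to 130 nM. The step this estimate implies, no change at the digits printed from compound 2 to compound 3 (within the scatter), is expected to stay within the scatter.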

Compound 3, half-maximal inhibitory concentration: 40 nM
Estimate against measurement, compound 3: 1.3-fold (0.10 log units) above; the measured number falls inside the stated range.
By their numbers in this assay, from the lowest: compounds 1, 3 and 2 (each within the scatter of the next).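

Placing chloro on an aromatic carbon ortho to a large group gives a 1.3-fold lower number from compound 2 to compound 3 (0.10 log units; within the scatter) in this assay, so this position accepts a chlorine atom with no shift that can be told from the scatter. Replacing 4-methylphenyl with 2-chlorophenyl on the aromatic nitrogen gives no change at the digits printed from compound 1 to compound 3 (within the scatter), so the phenyl, 4-methylphenyl and 2-chlorophenyl forms of the shared core cannot be ranked against one another. No independent evidence bears on this result.

The compounds shown leave open whether an amine or a carboxylic acid on this aromatic ring would move the number beyond the scatter. They also leave open whether a longer chain in place of the aromatic ring on the aromatic nitrogen would keep the number in this range.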